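Nitro in Place of Chloro on the Shared Core

The source may hold more compounds than are shown below. What is called first, only, known or untested is meant among the compounds shown, and "the series" means these compounds.

Three measured compounds share a core and differ at two places. Compound 1 `O=C(Cn1c(=O)oc2cc([N+](=O)[O-])ccc21)Nc1ccccn1` gives 38.6% in an ADME assay on RAW264.7 cells (Mus musculus) for cytotoxicity, read by MTT assay, with a stated time of 72 h, tested at 50 uM (a higher number here means a stronger effect of the compound at the concentration tested, a lower number a weaker effect), and compound 2 `O=C(Cn1c(=O)oc2cc([N+](=O)[O-])ccc21)Nc1ccccc1` gives 18%; the step between them, a number 20.6 percentage points lower from compound 1 to compound 2 (beyond the scatter), concerns the amide-type nitrogen only. Compound 3 `O=C(Cn1c(=O)oc2cc(Cl)ccc21)NCc1ccco1` gives 27.8%, the second highest of the three numbers, within the scatter of compound 2 and beyond the scatter from compound 1. Compound 4 `O=C(Cn1c(=O)oc2cc([N+](=O)[O-])ccc21)NCc1ccco1` differs from compound 3 by nitro in place of chloro on an aromatic carbon. No measured step changes this position, so nothing shown bears on it directly; the only recorded step touches another place. Compound 4 is therefore expected to give about 30%, between 15% and 45%. The expected step of a number 2.2 percentage points higher from compound 3 to compound 4 (within the scatter) stays within the scatter.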

Compound 4, a percentage reported as inhibition, at one concentration (the size of the read-out at that concentration, not a potency): 26.8%
Estimate against measurement, compound 4: 3.2 percentage points above; measured number inside the range.
By their numbers in this assay, from the lowest: compounds 2, 4 and 3 (each within the scatter of the next); then compound 1.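

In this assay, among these compounds, the first measured change at this position, nitro in place of chloro on an aromatic carbon, gives a number 1 percentage points lower from compound 3 to compound 4 (within the scatter) with (furan-2-yl)methyl on the amide-type nitrogen. With nitro held fixed, the group on that nitrogen still counts: there is a number 8.8 percentage points higher from compound 2 to compound 4 (within the scatter) for (furan-2-yl)methyl in place of phenyl, but a number 11.8 percentage points lower from compound 1 to compound 4 (beyond the scatter) for the same group in place of pyridin-2-yl, so among these three only pyridin-2-yl stands apart. No measurement here offers an explanation for these numbers. Open, on these data alone, is whether an amine or a methoxy group on this aromatic carbon would match chloro and nitro, and whether chloro would also leave the number unchanged with pyridin-2-yl on the nitrogen.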